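The source may report more compounds than this note shows. Statements on the series, on what has been measured and on what is new or still open speak of the compounds shown alone.

Compounds measured in an in vitro ADME assay on microsomes from liver (Homo sapiens) for pharmacokinetics, read by LC-MS, with a stated time of 10 min, tested at 1 uM; a higher number here means faster removal of the compound, a lower number slower removal:
compound 1 `Cc1ccc(NC(=O)[C@H]2CN(C)C[C@@H]2c2ccc(/C=C/C(=O)Nc3ccccc3N)cc2)cc1` gives 15 mL/min/kg;
compound 2 `CN1C[C@H](C(=O)Nc2ccc(C#N)cc2)[C@@H](c2ccc(/C=C/C(=O)Nc3ccccc3N)cc2)C1` gives 1 mL/min/kg;
compound 3 `CC(C)c1ccc(NC(=O)[C@H]2CN(C)C[C@@H]2c2ccc(/C=C/C(=O)Nc3ccccc3N)cc2)cc1` gives 10 mL/min/kg.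

Compound 3 stands second highest of the three numbers; the step of a 1.5-fold lower number from compound 1 to compound 3 (0.18 log units; within the scatter) is within the scatter, while a 10-fold higher number from compound 2 to compound 3 (1.00 log units; beyond the scatter) is beyond it. As far as these compounds go, compound 4 `CN1C[C@H](C(=O)Nc2ccc(F)c(Cl)c2)[C@@H](c2ccc(/C=C/C(=O)Nc3ccccc3N)cc2)C1` is untested; it differs from compound 3 as follows: 3-chloro-4-fluorophenyl in place of 4-isopropylphenyl on an amide-type nitrogen. Among the measured compounds shown here, all three earlier steps change the group on the same amide-type nitrogen, and a 15-fold lower number from compound 1 to compound 2 (1.18 log units; beyond the scatter) shows that such a change can move the number far; no measured compound carries a halogenated ring here, so the direction is open. An intermediate number is expected, a 1.7-fold lower number from compound 3 to compound 4 (0.22 log units; within the scatter), with wide uncertainty. Compound 4 is estimated at 6 mL/min/kg, range 1.5 mL/min/kg to 20 mL/min/kg.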

Compound 4, clearance: 15 mL/min/kg
For compound 4 the middle estimate is 2.5-fold (0.40 log units) below the measured one, within the range that was stated.
By their numbers in this assay, from the lowest: compound 2; then compounds 3, 1 and 4 (each within the scatter of the next).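

At this amide-type nitrogen, 3-chloro-4-fluorophenyl does not separate from the alkyl-bearing rings in this assay, with a 1.5-fold higher number from compound 3 to compound 4 (0.18 log units; within the scatter) and no change at the digits printed from compound 1 to compound 4 (within the scatter) as its two steps. Against that, a 15-fold higher number from compound 2 to compound 4 (1.18 log units; beyond the scatter) leaves 4-cyanophenyl as the only ring here set apart from the other three. No measurement on hand accounts for this grouping.

As far as these compounds go, whether the low number of compound 2 is particular to the nitrile or also appears with a carboxylic acid or an amine on this ring stays open. So does what the chlorine and the fluorine each contribute alone.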